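Furan-2-yl in place of 4-chlorophenyl on the shared core

This account rests on a few compounds, and the source may have more. Where it says the series, first, only, none or still open, it means among the compounds named here.

Compound 1 `O=C(O)c1cccc(Cc2c(-c3ccccc3)nn3cc(Br)ccc23)n1` and compound 2 `O=C(O)c1cccc(Cc2c(-c3ccc(Cl)cc3)nn3cc(Cl)ccc23)n1` share one core and have both been run in a functional assay on cells for antagonist activity at prostaglandin E2 receptor EP1 subtype (Rattus norvegicus), read by fluorescence and calcium flux, with a stated time of 60 s; a lower number here means a stronger inhibitor, a higher number a weaker inhibitor. In this assay compound 1 gives 11 nM. Compound 2 gives 1100 nM in this assay, the highest of the two numbers, and its gap to compound 1 lies well beyond the scatter. The two compounds differ in more than one place, so the gap cannot be tied to any single change.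

Compound 3 `O=C(O)c1cccc(Cc2c(-c3ccco3)nn3cc(Cl)ccc23)n1` has not been measured. It keeps compound 2 except at one position: furan-2-yl in place of 4-chlorophenyl on an aromatic carbon. Among the measured compounds shown here, no measured pair differs in this place alone, so no measured step guides the expectation, and compound 2 is the only direct reference. The change is expected to lower the number, but with wide uncertainty, since nothing in the measured data shows how this ring behaves. For compound 3 the expected step is a 3.7-fold lower number from compound 2 to compound 3 (0.56 log units; beyond the scatter). Compound 3 is estimated at 300 nM in this assay, within a range from 40 nM to 3000 nM.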

Compound 3, half-maximal inhibitory concentration: 1200 nM
Compound 3: middle estimate off by 4.0-fold (0.60 log units), on the low side, and the stated range covers the measured number.
By their numbers in this assay, from the lowest: compound 1; then compounds 2 and 3 (each within the scatter of the next).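

In this assay, the series now has its first comparison that differs in one place: a 1.1-fold higher number from compound 2 to compound 3 (0.04 log units; within the scatter), with furan-2-yl in place of 4-chlorophenyl on an aromatic carbon of the five-membered aromatic ring with 2 nitrogen. On the background of compound 2, a change from a six-membered aromatic ring of carbon only to a five-membered aromatic ring with 1 hetero atom, going from 7 heavy atoms to 5 and gaining 1 hydrogen-bond acceptor, therefore gives no step beyond the scatter. Nothing available accounts for this result, so the reading stays a plain observation on this one pair.

From the compounds shown here alone, whether the same holds on the core of compound 1, which carries a bromine and an unsubstituted phenyl group, remains open, since only this one background has a step at the position. Also open, going by these compounds, is how a group of a different kind at this position, such as an amine or a longer chain ending in a carboxylic acid, would read in this assay.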